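The source may hold more compounds than are shown below. What is called first, only, known or untested is meant among the compounds shown, and "the series" means these compounds.

Measured in a functional assay on RKO cells (Homo sapiens) for cytotoxicity, read by MTT assay, with a stated time of 48 h; on this read-out lower numbers stand for stronger inhibition and higher numbers for weaker inhibition:
- compound 1 `CN(C)CCNc1ccnc2cc(OCc3ccc(F)cc3)ccc12`: 580 nM
- compound 2 `Fc1ccc(COc2ccc3c(Cl)ccnc3c2)cc1`: 1980 nM

Compound 1 holds the lower of these two numbers, so it is the stronger inhibitor here. The next compound to consider is compound 3 `CCCCCCOc1ccc2c(NCCN(C)C)ccnc2c1`, which differs from compound 1 at one place: pentyl in place of 4-fluorophenyl on a saturated chain carbon bound to an oxygen on an aromatic ring. In words, this is pentyl in place of 4-fluorophenyl on a saturated chain carbon bound to an oxygen on an aromatic ring, or 4-fluorobenzyl to hexyl when cut one bond further out.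

Among the compounds with values here, only one measured step exists, a 3.4-fold higher number from compound 1 to compound 2 (0.53 log units; beyond the scatter). It changes a different place, so it gives a sense of scale but no direction. Within the data shown here, with no measured step at this place, a modest change is expected, leaning slightly towards a higher number in this assay. The expected change is a 1.6-fold higher number from compound 1 to compound 3 (0.19 log units; within the scatter). For compound 3 the estimated value is 900 nM, with an expected range of 300 nM to 2700 nM.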

Compound 3, half-maximal inhibitory concentration: 1120 nM
For compound 3 the middle estimate is 1.2-fold (0.09 log units) below the measured one; the range from low to high includes it.
By their numbers in this assay, from the lowest: compounds 1, 3 and 2 (each within the scatter of the next, the first and the last beyond it).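

At this place, on a saturated chain carbon bound to an oxygen on an aromatic ring, exchanging 4-fluorophenyl for pentyl gives a 1.9-fold higher number from compound 1 to compound 3 (0.29 log units; within the scatter) in this assay. The six-membered aromatic ring and its fluorine can therefore both be absent without the number moving beyond the usual scatter, so in this pair, an open carbon chain serves about as well as the 4-fluorobenzyl group. No supporting evidence is available to explain why these two different groups give similar numbers.

A single pair cannot separate the contribution of the ring from that of the fluorine, so plain benzyl, without fluorine, would be an informative group at this place. A shorter chain such as ethyl or a longer one such as octyl could show whether chain length matters here at all.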